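Compound 4 and the Ester in Place of the Aryl Ether

A few compounds are considered here, and "the series" means these few. Any claim that something is new, unique, unknown or untested is made for them only; others in the source may bear on it.

Measured in a functional assay on RAW264.7 cells (Mus musculus) for inhibition, read by Griess assay, with stated times of 3 h and 24 h; on this read-out higher numbers stand for weaker inhibition and lower numbers for stronger inhibition:
- compound 1 `C=C1CCC2[C@](C)(CO)[C@H](O)CC[C@@]2(C)[C@@H]1CCn1ccc(=O)[nH]c1=O`: > 100000 nM
- compound 2 `C=C1CCC2[C@](C)(CO)[C@H](O)CC[C@@]2(C)[C@@H]1CCOc1ccccc1O`: 47700 nM
- compound 3 `C=C1CCC2[C@](C)(CO)[C@H](O)CC[C@@]2(C)[C@@H]1CCOc1ccc(Br)cc1`: 40300 nM

Not yet measured: compound 4 `C=C1CCC2[C@](C)(CO)[C@H](O)CC[C@@]2(C)[C@@H]1CCOC(=O)c1cccnc1`.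

The value for compound 1 is a limit of the assay and not a number. Compound 3 stands level with compound 2, and the two numbers lie within the scatter of each other. Compound 4 carries (pyridin-3-yl)carbonyl in place of 4-bromophenyl on an oxygen on a saturated carbon.

The closest measured change on that oxygen is a 1.2-fold lower number from compound 2 to compound 3 (0.07 log units; within the scatter). The larger steps, an at least 2.0-fold lower number from compound 1 to compound 2 (0.32 log units; beyond the scatter) and an at least 2.4-fold lower number from compound 1 to compound 3 (0.39 log units; beyond the scatter), both start from the limit and replace a ring with two hetero atoms. Going by the values given here, no measured compound carries this carbonyl, so the range stays wide and reaches towards the limit. No shift beyond the scatter is expected, and the estimated change is a 1.2-fold higher number from compound 3 to compound 4 (0.09 log units; within the scatter). For compound 4 the expected value is 50000 nM, with an estimated range of 18000 nM to 100000 nM.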

Compound 4, half-maximal inhibitory concentration: > 50000 nM
Compound 4 gave a limit, no number; the forecaster's own chance of this, stated with the estimate: 15%; the middle value sits exactly at the limit.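

With (pyridin-3-yl)carbonyl on this oxygen, the read-out for compound 4 in this assay ends at a limit of the assay and not at a number: the limit of > 50000 nM in this assay, at which 1 of the 4 values shown sits.

Read as floors, an at least 1.2-fold higher number from compound 3 to compound 4 (0.09 log units; that floor lies within the scatter) and an at least 1.0-fold higher number from compound 2 to compound 4 (0.02 log units; that floor lies within the scatter) show that replacing the aryl ether with this ester brings no lower number than the two ethers, but they do not show a loss beyond the scatter. The step between compound 1 and compound 4 cannot be read, as both ends are limits.

From the compounds shown here alone, it remains open whether the carbonyl or the ring nitrogen goes with this result, and how far the true value of compound 4 lies past its limit. A benzoyl group or a pyridin-3-yl group on the same oxygen would separate the two.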